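The source may hold more compounds than are shown below. What is called first, only, known or untested is meant among the compounds shown, and "the series" means these compounds.

Measured in an ADME assay on HepG2 cells (Homo sapiens) for cytotoxicity, read by MTT assay, with a stated time of 48 h; on this read-out higher numbers stand for weaker inhibition and lower numbers for stronger inhibition:
- compound 1 `O=S(=O)(c1cccc(-c2ccc3ncnc(Nc4ccc(OCc5cccc(F)c5)c(Cl)c4)c3c2)c1)N1CCCCC1`: > 15000 nM, a limit
- compound 2 `O=S(=O)(c1ccc(-c2ccc3ncnc(Nc4ccc(OCc5cccc(F)c5)c(Cl)c4)c3c2)cc1)N1CCCC1`: > 15000 nM, a limit
- compound 3 `O=S(=O)(c1ccc(-c2ccc3ncnc(Nc4ccc(OCc5cccc(Cl)c5)c(Cl)c4)c3c2)cc1)N1CCOCC1`: > 15000 nM, a limit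

No number is available for any of the three: the limit of > 15000 nM in this assay, at which 3 of the 3 values shown sit. Compound 3 therefore stands only at its limit of > 15000 nM.

Compound 4 `O=S(=O)(c1ccc(-c2ccc3ncnc(Nc4ccc(OCc5cc(F)cc(F)c5F)c(Cl)c4)c3c2)cc1)N1CCOCC1` carries 2,3,5-trifluorophenyl in place of 3-chlorophenyl on a saturated chain carbon bound to an oxygen on an aromatic ring. Among the compounds with values here, no measured pair gives the size of such a change. In this assay, no shift beyond the scatter is expected, and this expectation rests on the limit of compound 3 at > 15000 nM. The expected change is a step that the limit leaves unreadable from compound 3 to compound 4. For compound 4 the estimated value is 20000 nM, with an expected range of 9000 nM to 45000 nM.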

Compound 4, half-maximal inhibitory concentration: > 3000 nM
Compound 4: no number, only a limit; the forecaster's own chance of this, stated with the estimate: 75%; the middle value does not contradict the limit.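

Within the data shown here, compound 3 and compound 4 give only limits in this assay, and no step between them can be read. The compounds shown leave open whether 2,3,5-trifluorophenyl in place of 3-chlorophenyl shifts this read-out at all.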